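The compounds below may be only part of what the source reports. "The series", "measured", "known", "first", "only" and "open" are said of these compounds alone.

Measured compounds:
compound 1 `Cc1csc(-c2cccc(CN(C)c3ccc4[nH]nc(C(=O)O)c4c3)c2)n1` — 650 nM
compound 2 `O=C(O)c1nnsc1Sc1ccc(Cl)cc1` — > 30000 nM

In an assay on isolated protein for inhibition of 2-Hydroxyacid oxidase 1 (Homo sapiens), with stated times of 30 min and 15 min (on this read-out higher numbers stand for weaker inhibition and lower numbers for stronger inhibition), compound 1 gives 650 nM, the only actual number among the two results shown. Compound 2, a compound of quite different build, returns only > 30000 nM, which is a limit of this assay and not a measured number; one of the two values therefore sits at the limit of > 30000 nM in this assay, at which 1 of the 2 values shown sits. Going by the values given here, no pair of measured compounds differs in a single place, so no measured step is available for comparison.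

Compound 3 `CC(C)c1csc(-c2cccc(CN(C)c3ccc4[nH]nc(C(=O)O)c4c3)c2)n1` shares the core of compound 1 and differs from it in one place: isopropyl in place of methyl on an aromatic carbon. Among the compounds with values here, with no measured step to guide the expectation, the change is small in scope and is not expected to move the result beyond the usual scatter of this assay; the step of a 1.1-fold higher number from compound 1 to compound 3 (0.03 log units; within the scatter) is estimated to be close to none, with a slight chance of a modest shift in either direction. Compound 3 is accordingly expected to give about 700 nM in this assay, with a range from 250 nM to 2000 nM.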

Compound 3, half-maximal inhibitory concentration: 710 nM
Compound 3: the middle estimate sits 1.0-fold (0.01 log units) below what was measured, and the stated range covers the measured number.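

In this assay, going by these compounds alone, isopropyl in place of methyl on an aromatic carbon of the five-membered ring gives a 1.1-fold higher number from compound 1 to compound 3 (0.04 log units; within the scatter), and this is the first step between two measured compounds that differ in one place. The position, next to the ring nitrogen and two ring bonds from the ring sulfur, therefore holds isopropyl as well as methyl, and compound 1 and compound 3 cannot be told apart on this read-out. No measurement shown bears on why these two compounds read alike.

With only methyl and isopropyl seen at this position, the compounds shown leave open whether a tert-butyl group, a cyclopropyl ring, an amine or a carboxylic acid on the same carbon would also give a value within the scatter of these two. They also leave open how the rest of the shared core responds to change, for instance whether the methyl on the linking nitrogen could give way to hydrogen or to an ethyl group.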